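Hydroxyphenyl series on HCT-15 cells: a positional isomer of compound 3

The source may hold more compounds than are shown below. What is called first, only, known or untested is meant among the compounds shown, and "the series" means these compounds.

Measured so far:
compound 1, `Oc1cccc(-c2cc(-c3cccs3)cc(-c3ccccc3O)n2)c1`, gives in a functional assay on HCT-15 cells (Homo sapiens) for cytotoxicity, read by CCK-8 assay (on this read-out higher numbers stand for weaker inhibition and lower numbers for stronger inhibition), only a limit, > 50000 nM.
compound 2, `Oc1cccc(-c2cc(-c3ccco3)cc(-c3ccccc3O)n2)c1`, gives in this assay only a limit, > 50000 nM.
compound 3, `Oc1ccccc1-c1cc(-c2ccoc2)cc(-c2ccccc2O)n1`, gives in this assay only a limit, > 50000 nM.

Compound 3 stands at the limit of the assay, and so do the two other measured compounds: the limit of > 50000 nM in this assay, at which 3 of the 3 values shown sit. For the measured compounds named here, the one measured change that is shared by two compounds, a step that the two limits leave unreadable from compound 1 to compound 2, cannot be read because both ends are limits.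

Compound 4, `Oc1cccc(-c2cc(-c3ccoc3)cc(-c3ccccc3O)n2)c1`, differs from compound 3 in one place: 3-hydroxyphenyl in place of 2-hydroxyphenyl on an aromatic carbon. Going by the values given here, none of the measured steps concerns exchanging a 2-hydroxyphenyl group for a 3-hydroxyphenyl group, so no measured step bears on this change, and the only readable information is that every compound so far sits at the limit.

The step from compound 3 to compound 4 is therefore expected to stay within the scatter, a step that the limit leaves unreadable from compound 3 to compound 4, in no readable direction. For compound 4 in this assay the estimate is 70000 nM, with a range from 30000 nM to 200000 nM, and most likely the assay will again report only a limit.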

Compound 4, half-maximal inhibitory concentration: > 50000 nM
Compound 4: only a limit was reported; the forecaster's own chance of this, stated with the estimate: 85%; the middle value does not contradict the limit.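

In this assay compound 4 gives > 50000 nM as a limit only. Its steps from compound 1, compound 2 and compound 3 cannot be read, since all four values are limits: the limit of > 50000 nM in this assay, at which 4 of the 4 values shown sit.

The compounds shown leave open whether exchanging the furan-2-yl, furan-3-yl, thiophen-2-yl, 2-hydroxyphenyl or 3-hydroxyphenyl groups has any effect in this assay at all.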